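Aryl swap on the shared core: methoxyphenyl to dichlorophenyl

This account rests on a few compounds, and the source may have more. Where it says the series, first, only, none or still open, it means among the compounds named here.

Compound 1 `COc1ccc(-c2cnc3cc4c(cc3n2)C2CNCC4C2)cc1` gives 26 nM in an assay for binding affinity to Neuronal acetylcholine receptor; alpha4/beta2 (Rattus norvegicus) (a higher number here means a weaker inhibitor, a lower number a stronger inhibitor), the highest number of the two in hand, though the gap to compound 2 `c1ccc(-c2nc3cc4c(cc3[nH]2)C2CNCC4C2)cc1`, which gives 14 nM in this assay, lies within the scatter. Compound 3 `Clc1ccc(-c2cnc3cc4c(cc3n2)C2CNCC4C2)c(Cl)c1` differs from compound 1 by 2,4-dichlorophenyl in place of 4-methoxyphenyl on an aromatic carbon. Within the data shown here, no step between measured compounds covers this kind of change, so the data give no direction; the step of a 1.2-fold higher number from compound 1 to compound 3 (0.06 log units; within the scatter) is expected to be small, within the scatter or only just beyond it. Compound 3 is estimated at 30 nM, with a range from 8 nM to 110 nM.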

Compound 3, inhibition constant: 88 nM
The estimate for compound 3 lay 2.9-fold (0.47 log units) below the measured number; the measured number falls inside the stated range.
By their numbers in this assay, from the lowest: compounds 2 and 1 (each within the scatter of the next); then compound 3.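

This position on the shared core responds to the aryl group: in this assay, 2,4-dichlorophenyl in place of 4-methoxyphenyl gives a 3.4-fold higher number from compound 1 to compound 3 (0.53 log units; beyond the scatter) and this is the only listed step, lying beyond the scatter. The two groups have the same heavy-atom count, so that count does not account for the step; the hydrogen-bond acceptor of 4-methoxyphenyl is lost, but nothing ties the step to that loss. No available measurement bears on the cause of the step.

Open, on these data alone, is whether one chlorine on the phenyl ring gives a similar step. A pyridyl ring or an aminophenyl group at this position also remains untested within the compounds shown.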